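A Ring Swap on the Ether Chain of Compound 1

The compounds below may be only part of what the source reports. "The series", "measured", "known", "first", "only" and "open" are said of these compounds alone.

Measured so far in an assay on isolated protein for inhibition of protein deacetylase HDAC6 (Homo sapiens), read by fluorescence, with a stated time of 30 min; a lower number here means a stronger inhibitor, a higher number a weaker inhibitor:
Compound 1, `COc1cc2c(NCC3CCN(c4ncc(C(=O)NO)cn4)CC3)cc(-c3ccc(C)o3)nc2cc1OCCCN1CCCC1`, gives 152 nM.
Compound 2, `COc1cc2c(NCC3CCN(Cc4ccc(C(=O)NO)cc4)CC3)cc(-c3ccc(C)o3)nc2cc1OCCCN1CCCC1`, gives 53 nM.
Compound 3, `COc1cc2c(NCC3CCN(c4ncc(C(=O)NO)cn4)CC3)cc(C)nc2cc1OCCCN1CCCC1`, gives 350 nM.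

Among these three, compound 1 sits in the middle: there is a 2.9-fold lower number from compound 1 to compound 2 (0.46 log units; beyond the scatter), and there is a 2.3-fold higher number from compound 1 to compound 3 (0.36 log units; beyond the scatter). Both of those steps are modest, and both lie beyond the scatter, so compound 2 reads as the stronger inhibitor of the set and compound 3 as the weaker.

Compound 4, `COc1cc2c(NCC3CCN(c4ncc(C(=O)NO)cn4)CC3)cc(-c3ccc(C)o3)nc2cc1OCC1CCNCC1`, has not yet been measured. It differs from compound 1 in one place: piperidin-4-yl in place of 2-(pyrrolidin-1-yl)ethyl on a saturated chain carbon bound to an oxygen on an aromatic ring. Neither measured step touches this part of the shared core. The step to compound 2 alters the group on the ring nitrogen, and the step to compound 3 alters the group on the aromatic carbon; the chain on the ether oxygen is the same in all three measured compounds. For the measured compounds named here, there is therefore no measured step that bears on the change from compound 1 to compound 4, and no basis for expecting a shift in either direction beyond the scatter of this assay.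

On that reasoning, compound 4 is expected to give about 150 nM, within a range of 55 nM to 420 nM, which amounts to an expected step of a 1.0-fold lower number from compound 1 to compound 4 (0.01 log units; within the scatter).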

Compound 4, half-maximal inhibitory concentration: 351 nM
Beside the measured number, compound 4's estimate is 2.3-fold (0.37 log units) below it, within the range that was stated.
By their numbers in this assay, from the lowest: compound 2; then compound 1; then compounds 3 and 4 (each within the scatter of the next).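

The ether chain is the one part that stayed the same across compounds 1 to 3, and this result shows that changing it moves the number: putting piperidin-4-yl in place of 2-(pyrrolidin-1-yl)ethyl gives a 2.3-fold higher number from compound 1 to compound 4 (0.36 log units; beyond the scatter), so compound 4 is the weaker inhibitor of this pair. This step is also graded modest, like the two earlier single changes (a 2.9-fold lower number from compound 1 to compound 2 (0.46 log units; beyond the scatter); a 2.3-fold higher number from compound 1 to compound 3 (0.36 log units; beyond the scatter)), so this position joins the other two as a place where one change shifts the number beyond the scatter. Nothing available explains the step, which at once replaces a five-membered ring with a six-membered one, adds a hydrogen-bond donor, and turns 3-(pyrrolidin-1-yl)propoxy into (piperidin-4-yl)methoxy.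

Which of these differences carries the step stays open, and a 3-(piperidin-1-yl)propoxy chain, or a methyl group on the piperidine nitrogen of compound 4, would begin to pull them apart. On these data alone, it is also open whether the same swap would act alike with the 4-(hydroxycarbamoyl)benzyl group of compound 2 in place.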